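Imidazole for Pyrrolidine on a Butynyl Chain in Mice

This account rests on a few compounds, and the source may have more. Where it says the series, first, only, none or still open, it means among the compounds named here.

Compound 1, `COC(=O)N(C)CC#CCN1CCCC1`, gives 3 mg/kg in a functional assay on the whole organism for agonist activity, with Mus musculus as the target; a higher number here means that more compound is needed for the effect, a lower number that less compound is needed.
Compound 2, `COC(=O)N(C)CC#CCn1ccnc1`, gives 4.5 mg/kg in this assay.
Compound 3, `Cn1ccn(CC#CCN2CCCC2)c1=O`, gives 6.6 mg/kg in this assay.

Compound 1 and compound 2 share a core and differ in one place: 1H-imidazol-1-yl in place of pyrrolidin-1-yl on a saturated chain carbon bound to a triple-bonded carbon. That change gave a 1.5-fold higher number from compound 1 to compound 2 (0.18 log units; within the scatter), so the two doses cannot be told apart. Compound 3 carries a different core; the difference between the two cores is not broken down here. Its dose and that of compound 2 lie within the scatter of each other, while its dose and that of compound 1 lie beyond it.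

Compound 4, `Cn1ccn(CC#CCn2ccnc2)c1=O`, has not yet been tested. It stands to compound 3 as compound 2 stands to compound 1: 1H-imidazol-1-yl in place of pyrrolidin-1-yl on a saturated chain carbon bound to a triple-bonded carbon. The place is the same word for word, so this is the same change, seen once before. Because the earlier step was a 1.5-fold higher number from compound 1 to compound 2 (0.18 log units; within the scatter), the expectation is a step of about a 1.5-fold higher number from compound 3 to compound 4 (0.18 log units; within the scatter), with wide room in the estimate because the change rests on a single measured pair. Compound 4 is expected to give roughly 10 mg/kg in this assay, likely between 5 mg/kg and 20 mg/kg.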

Compound 4, dose for half-maximal effect: 4.4 mg/kg
The estimate for compound 4 lay 2.3-fold (0.36 log units) above the measured number; the measured number lies below the stated range.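

On the core of compound 3, putting 1H-imidazol-1-yl in place of pyrrolidin-1-yl gave a 1.5-fold lower number from compound 3 to compound 4 (0.18 log units; within the scatter) in this assay, so this pair of doses, like the earlier pair, cannot be told apart. Set side by side, the two steps also cannot be told apart: the same change on two cores in this assay, a 1.5-fold higher number (0.18 log units; within the scatter) from compound 1 to compound 2 and a 1.5-fold lower number (0.18 log units; within the scatter) from compound 3 to compound 4, 2.3-fold (0.35 log units) apart, within the scatter of two such steps. Among these compounds, this shows that on both cores the change left no difference that stands out from the scatter of the measurements, but with only two pairs, it does not show that the change would behave the same way on any further core, and it gives no reason for the result.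

The compounds shown leave open how an open-chain amine such as dimethylamino, or a piperidin-1-yl ring, would compare on a saturated chain carbon bound to a triple-bonded carbon. They also leave open whether a longer chain would let this same change produce a step beyond the scatter.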